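From pyridin-4-yl to pyridin-3-yl on a carbonyl carbon

The compounds below may be only part of what the source reports. "The series", "measured", "known", "first", "only" and "open" are said of these compounds alone.

In a functional assay on MCF7 cells (Homo sapiens) for antiproliferative activity, with a stated time of 5 days (on this read-out lower numbers stand for stronger inhibition and higher numbers for weaker inhibition), compound 1 `CCCCc1ccc2[nH]c(-c3ccc(C(F)(F)F)cc3)c(/C=N/NC(=O)c3ccccc3)c2c1` gives 460 nM on this read-out. Among the measured compounds shown here, compound 2 `CCCCc1ccc2[nH]c(-c3ccc(C(F)(F)F)cc3)c(/C=N/NC(=O)c3ccncc3)c2c1` gives 100 nM and so holds the lower of the two numbers measured so far. The next compound, compound 3 `CCCCc1ccc2[nH]c(-c3ccc(C(F)(F)F)cc3)c(/C=N/NC(=O)c3cccnc3)c2c1`, keeps the shared core and changes one group: pyridin-3-yl in place of pyridin-4-yl on a carbonyl carbon.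

For the measured compounds named here, only one measured step bears on this change. Pyridin-4-yl in place of phenyl on the same carbonyl carbon gave a 4.6-fold lower number from compound 1 to compound 2 (0.66 log units; beyond the scatter) in a modest step beyond the scatter. Going by the values given here, no measurement yet shows how pyridin-3-yl compares with pyridin-4-yl. Because compound 2 gives 100 nM and compound 3 has a pyridinyl group like compound 2, compound 3 is expected to lie nearer to the number of compound 2 than to the number of compound 1.

The expected step is a 1.7-fold higher number from compound 2 to compound 3 (0.23 log units; within the scatter) at its middle, small and leaning towards a higher number. In this assay the estimated value of compound 3 is 170 nM with an expected range from 75 nM to 420 nM in this estimate.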

Compound 3, half-maximal inhibitory concentration: 260 nM
Compound 3: the middle estimate sits 1.5-fold (0.18 log units) below what was measured, and the stated range covers the measured number.
By their numbers in this assay, from the lowest: compound 2; then compounds 3 and 1 (each within the scatter of the next).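

In this assay the position on the carbonyl carbon responds to which pyridinyl group sits there, and not only to whether one does: the exchange gives a 2.6-fold higher number from compound 2 to compound 3 (0.41 log units; beyond the scatter) even though the two groups have the same atoms and the same counts of donors and acceptors. Set against phenyl, pyridin-3-yl gives a 1.8-fold lower number from compound 1 to compound 3 (0.25 log units; within the scatter) and so cannot be told apart from phenyl in this series, whereas pyridin-4-yl gave a 4.6-fold lower number from compound 1 to compound 2 (0.66 log units; beyond the scatter) and the clear step away from phenyl therefore belongs, among these three compounds, to pyridin-4-yl alone and not to pyridinyl groups in general. Nothing available here accounts for the difference between the two pyridinyl groups.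

The compounds shown leave open how pyridin-2-yl, or a phenyl carrying an amine or a carboxylic acid, would read on the same carbonyl carbon. They also leave open whether the gap between pyridin-4-yl and pyridin-3-yl would persist if the butyl chain gave way to a methyl or a longer hexyl chain, since all three compounds share that chain and the rest of the core.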